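Benzylsulfonyl for (Chloromethyl)carbonyl: an Expected Cytotoxicity Step

The source may hold more compounds than are shown below. What is called first, only, known or untested is meant among the compounds shown, and "the series" means these compounds.

Compound 1, `C=CCOc1cc(/C=C/C(=O)c2ccc(OC)c3c2OC(C)(C)C=C3)ccc1OC`, is reported in a functional assay on A-375 cells (Homo sapiens) for cytotoxicity, read by MTT assay (on this read-out lower numbers stand for stronger inhibition and higher numbers for weaker inhibition), only as a limit: > 10000 nM.
Compound 2, `C=CC(=O)Oc1cc(/C=C/C(=O)c2ccc(OC)c3c2OC(C)(C)C=C3)ccc1OC`, gives 390 nM.
Compound 3, `COc1ccc(/C=C/C(=O)c2ccc(OC)c3c2OC(C)(C)C=C3)cc1OC(=O)CCl`, gives 450 nM.

Compound 3 holds the higher of the two numbers shown, yet its neighbour is compound 2, with a 1.2-fold higher number from compound 2 to compound 3 (0.06 log units; within the scatter). Compound 4, `COc1ccc(/C=C/C(=O)c2ccc(OC)c3c2OC(C)(C)C=C3)cc1OS(=O)(=O)Cc1ccccc1`, differs from compound 3 by benzylsulfonyl in place of (chloromethyl)carbonyl on an oxygen on an aromatic ring. For the measured compounds named here, the steps that bear on this are an at least 25-fold lower number from compound 1 to compound 2 (1.40 log units; beyond the scatter) and an at least 22-fold lower number from compound 1 to compound 3 (1.34 log units; beyond the scatter), both large, while a 1.2-fold higher number from compound 2 to compound 3 (0.06 log units; within the scatter) was small. Going by the values given here, no measured compound carries a sulfonyl, so the estimate stays wide: compound 4 is expected to show a 3.3-fold higher number from compound 3 to compound 4 (0.52 log units; beyond the scatter). Compound 4 is therefore estimated at 1500 nM, between 300 nM and 8000 nM.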

Compound 4, half-maximal inhibitory concentration: > 10000 nM
Compound 4: a limit, no number (the forecaster's own chance of this, stated with the estimate: 15%); middle value at least 6.6-fold (0.82 log units) from the limit.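

In this assay compound 4 is reported only as a limit, as compound 1 is, so benzylsulfonyl on this oxygen joins allyl rather than the two carbonyl groups. The steps of an at least 22-fold higher number from compound 3 to compound 4 (1.34 log units; beyond the scatter) and an at least 25-fold higher number from compound 2 to compound 4 (1.40 log units; beyond the scatter) are both large, showing that this position does not accept every group placed on the oxygen. The step between compound 1 and compound 4 cannot be read because both sit at a limit: the limit of > 10000 nM in this assay, at which 2 of the 4 values shown sit.

The compounds shown leave open whether the sulfonyl or the benzyl part goes with this loss. Methylsulfonyl, which has the sulfonyl without the ring, would separate the two, and acetyl would test the carbonyl without a chlorine or a vinyl.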